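The source may report more compounds than this note shows. Statements on the series, on what has been measured and on what is new or still open speak of the compounds shown alone.

Measured compounds:
- compound 1, `CN(C)/C(=N\C#N)C1=CC(C)(C)Oc2ccc(S(C)(=O)=O)cc21`: "nt" (no result reported) in a functional assay on the whole organism (aorta) with Rattus norvegicus as the target; a higher number here means a larger maximal response, a lower number a smaller maximal response
- compound 2, `CNC(=O)C1=CC(C)(C)Oc2ccc([N+](=O)[O-])cc21`: 61% in this assay

Among the measured compounds shown here, compound 2 is the only compound here with a number in this assay; compound 1 carries no result there, so nothing can be said about how the two compare. Compound 2 therefore stands alone as the reference point, and it reaches 61% in this assay, a little more than half of the largest response the reference agonist produces.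

Compound 3, `CN(C)C(=S)C1=CC(C)(C)Oc2ccc([N+](=O)[O-])cc21`, is the next compound to be tested in this assay. It keeps the shared core of compound 2 and changes only the group on the double-bonded ring carbon: a group of 5 heavy atoms (3 carbon, 1 nitrogen, 1 sulfur; no ring) in place of a group of 4 heavy atoms (2 carbon, 1 nitrogen, 1 oxygen; no ring), on a double-bonded ring carbon. The leaving methylcarbamoyl group brings one hydrogen-bond donor; the entering group brings none, and it carries a sulfur in place of an oxygen.

For the measured compounds named here, no measured pair in this set shows how such a change plays out, so any expectation rests on compound 2 alone. A modest rise in maximal response is expected for compound 3, a step of about a number 11 percentage points higher from compound 2 to compound 3 (beyond the scatter) from compound 2, with a wide margin of uncertainty. The estimate for compound 3 in this assay is 72%, within a range from 48% to 96%.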

Compound 3, intrinsic activity: the largest response reached, in percent of the reference agonist's: 71.5%
Compound 3: middle estimate off by 0.5 percentage points, on the high side, and the stated range covers the measured number.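

In this assay, among the compounds shown here, replacing the methylcarbamoyl group on the double-bonded ring carbon gives the first readable step in this set, a number 10.5 percentage points higher from compound 2 to compound 3 (beyond the scatter), showing that the maximal response can shift with a change at this position. The entering group has 0 hydrogen-bond donors and carries a sulfur in place of an oxygen, yet the response does not fall, so with this shared core a hydrogen-bond donor in this group is not needed to reach the response seen for compound 3. This single step changes several things at once, including the atom swap, the heavy-atom count and the loss of the donor, and no measurement here bears on which of them matters.

The compounds shown leave open how much of the step belongs to the sulfur and how much to the rest of the group, a question that a dimethylcarbamoyl group at this position, with oxygen instead of sulfur, would help to separate. Also open, going by these compounds, is how a longer chain on the nitrogen, such as an ethyl group, or a ring-forming amine such as pyrrolidine would compare in this assay.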